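Thiophene sulfonyl piperazine series: nitro removal toward compound 4

The source may report more compounds than this note shows. Statements on the series, on what has been measured and on what is new or still open speak of the compounds shown alone.

Measured compounds:
compound 1 `COc1ccc(Oc2ccccc2-c2ccsc2S(=O)(=O)N2CCN(C(=O)Nc3ccc([N+](=O)[O-])cc3)CC2)cc1OC` with 17%
compound 2 `O=[N+]([O-])c1ccc(NC(=S)N2CCN(S(=O)(=O)c3sccc3-c3ccccc3Oc3ccc(O)c(O)c3)CC2)cc1` with 31%
compound 3 `COc1ccc(Oc2ccc([N+](=O)[O-])cc2-c2ccsc2S(=O)(=O)N2CCN(C(=S)Nc3ccc([N+](=O)[O-])cc3)CC2)cc1OC` with 16%

All three values come from an assay for binding affinity to Apoptosis regulator Bcl-2 (Homo sapiens), read by fluorescence polarization, with stated times of 30 min and 20 min, tested at 100 uM; on this read-out higher numbers stand for more inhibition at the one concentration tested (going by the name of the read-out) and lower numbers for less inhibition. Compound 3 sits at the low end of the three numbers in this assay. The nearest number is that of compound 1, which lies within the scatter of compound 3, so the two cannot be ordered against each other. Compound 2 lies beyond the scatter above compound 3, the only difference among these three that stands clear of measurement noise.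

The next compound, compound 4 `COc1ccc(Oc2ccccc2-c2ccsc2S(=O)(=O)N2CCN(C(=S)Nc3ccc([N+](=O)[O-])cc3)CC2)cc1OC`, has not been measured in this assay. Its relation to compound 3 is hydrogen in place of nitro on an aromatic carbon. No single-point comparison between measured compounds exists in this set, so the size of the step has to be guessed from neighbours rather than read off a matching pair.

Compound 1, which also carries the 3,4-dimethoxyphenoxy group without the nitro, gives 17% in this assay. Given that value for compound 1 and the value of compound 3, the step of a number 2 percentage points higher from compound 3 to compound 4 (within the scatter) is expected to be small and not beyond the scatter, in either direction. For compound 4 the estimate in this assay is therefore 18%, within a range from 5% to 35%.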

Compound 4, a percentage reported as inhibition, at one concentration (the size of the read-out at that concentration, not a potency): 16%
Estimate against measurement, compound 4: 2 percentage points above; low and high end bracket the measured number.
By their numbers in this assay, from the lowest: compounds 3, 4 and 1 (each within the scatter of the next); then compound 2.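

Working notes: in this assay, hydrogen in place of nitro on the aromatic carbon para to a 3,4-dimethoxyphenoxy group gives no change at the digits printed from compound 3 to compound 4 (within the scatter), so this position now has a direct single-place reading, and the nitro shows no effect on this read-out beyond the scatter. 3,4-Dimethoxyphenyl in place of 3,4-dihydroxyphenyl on the oxygen gives a number 15 percentage points lower from compound 2 to compound 4 (beyond the scatter), which ties the clear gap in this set to that single change, whereas the exchange of the sulfur-bearing group for the oxygen-bearing group on the amine nitrogen in a ring gives a number 1 percentage points lower from compound 1 to compound 4 (within the scatter) and so separates nothing. No measurement shown accounts for any of these steps.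

On these data alone, only nitro and hydrogen are compared on that aromatic carbon, so it remains open whether an amine or a carboxylic acid there would move the number beyond the scatter. Also open, as far as these compounds go, is whether the step between 3,4-dimethoxyphenyl and 3,4-dihydroxyphenyl keeps its size with nitro on that carbon, and how these single-concentration numbers would translate into potency.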